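Swapping the Amide-Nitrogen Aryl Group in Compound 1

A few compounds are considered here, and "the series" means these few. Any claim that something is new, unique, unknown or untested is made for them only; others in the source may bear on it.

Compound 1 `COc1ccc(NC(=O)CCCCCCNC(=O)C(O)(O)C(F)(F)F)cc1`: 1600000 nM
Compound 2 `O=C(CCCCCCNC(=O)C(O)(O)C(F)(F)F)Nc1ncc(-c2ccc(O)cc2)s1`: 2300000 nM
Compound 3 `O=C(CCCCCCNC(=O)C(O)(O)C(F)(F)F)Nc1ncc(-c2ccccc2)s1`: 2500000 nM

Of the compounds shown here, three sharing a trifluoromethyl-bearing chain have been tested in an assay on isolated protein for inhibition of histone deacetylase 4 (Homo sapiens), read by chemiluminescence, with a stated time of 3 h; on this read-out higher numbers stand for weaker inhibition and lower numbers for stronger inhibition. In this assay compound 1 gives 1600000 nM, compound 2 gives 2300000 nM and compound 3 gives 2500000 nM. The three numbers lie within the usual scatter of one another, so compound 1 does not stand apart from compound 2 or compound 3.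

Compound 4 `O=C(CCCCCCNC(=O)C(O)(O)C(F)(F)F)Nc1nc2ccccc2s1` is obtained from compound 1 by the change (1,3-benzothiazol-2-yl in place of 4-methoxyphenyl on an amide-type nitrogen). Among the measured compounds shown here, the only measured step, a 1.1-fold higher number from compound 2 to compound 3 (0.04 log units; within the scatter), concerns a hydroxy group on an aromatic ring, not the group on the amide nitrogen, so it does not bear directly on this change. What the data do show is that three different aryl groups on that nitrogen, in compounds 1, 2 and 3, give numbers within the scatter of one another. On that basis no step beyond the scatter is expected, a 1.3-fold higher number from compound 1 to compound 4 (0.10 log units; within the scatter), and compound 4 is estimated at 2000000 nM, with a range from 700000 nM to 6000000 nM.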

Compound 4, half-maximal inhibitory concentration: 430000 nM
Estimate against measurement, compound 4: 4.7-fold (0.67 log units) above; measured number outside the range, below it.
By their numbers in this assay, from the lowest: compound 4; then compounds 1, 2 and 3 (each within the scatter of the next).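

In this assay, among the compounds shown here, the earlier compounds stayed within the scatter of one another despite their different aryl groups on the amide-type nitrogen, so they gave no sign that this position could move the number. Placing 1,3-benzothiazol-2-yl there instead of 4-methoxyphenyl gives a 3.7-fold lower number from compound 1 to compound 4 (0.57 log units; beyond the scatter) and shows that the group at this position can matter, although the step is modest and rests on this single pair. Nothing measured here accounts for the step.

From the compounds shown here alone, it remains open which part of the 1,3-benzothiazol-2-yl group goes with the lower number. A 1,3-benzoxazol-2-yl group, with oxygen in place of the sulfur, or a plain phenyl group on the same nitrogen would help to separate the sulfur and the fused ring from the rest of the change.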